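Methoxyphenyl to Phenyl on a Shared Core

The compounds below may be only part of what the source reports. "The series", "measured", "known", "first", "only" and "open" are said of these compounds alone.

Of the compounds shown here, three built on one shared core have been tested in an assay on isolated protein for inhibition of glucose-6-phosphatase catalytic subunit 1 (Homo sapiens), read by inositol phosphate accumulation, with a stated time of 30 min, tested at 100 uM; on this read-out higher numbers stand for more inhibition at the one concentration tested (going by the name of the read-out) and lower numbers for less inhibition. Compound 1 `Cc1ccc(C2=CC(c3ccccc3)C3=C(CC(C)(C)CC3=O)N2)cc1` is reported as "not active" (no number reported), with no number attached. Compound 2 `CC1(C)CC(=O)C2=C(C1)NC(c1ccccc1)=CC2c1ccco1` gives 11.4%. Compound 3 `COc1ccc(C2=CC(c3ccccc3)C3=C(CC(C)(C)CC3=O)N2)cc1` gives 8.34%, the lower of the two numbers on record, and its nearest neighbour is compound 2, whose reading is higher by an amount that lies within the usual scatter of this kind of measurement, so the two cannot be told apart. Every reading so far is small at the single concentration tested.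

Compound 4 `CC1(C)CC(=O)C2=C(C1)NC(c1ccccc1)=CC2c1ccccc1` has not yet been measured. It differs from compound 3 in a single place: hydrogen in place of methoxy on an aromatic carbon. Cut one bond further out, the change reads 4-methoxyphenyl to phenyl. Going by the values given here, no pair of measured compounds shows this exact change, so there is no measured step to lean on. Compound 3 sits at 8.34%, and compound 2 stays close to it, so nothing in the data points to a large effect from this part of the molecule. The step of a number 0.3 percentage points lower from compound 3 to compound 4 (within the scatter) is therefore expected to be no larger than the scatter, in either direction. Compound 4 is expected to give about 8% in this assay, within a range from 0% to 20%. A report of no activity, as for compound 1, cannot be ruled out either.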

Compound 4, a percentage reported as inhibition, at one concentration (the size of the read-out at that concentration, not a potency): "not active" (no number reported)
The entry for compound 4 holds no number; no gap can be computed for the estimate.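

In this assay, going by these compounds alone, compound 4 gives "not active" (no number reported) and so carries no number to set against compound 3, which means no step between compound 3 and compound 4 can be read. The compounds shown leave open whether changing 4-methoxyphenyl to phenyl alters inhibition at all. No measurement shown offers an explanation for this result.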